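The source may hold more compounds than are shown below. What is called first, only, known or untested is meant among the compounds shown, and "the series" means these compounds.

Compound 1 `CC(C)C1=CC[C@H](CO)[C@@]12C=CC(=O)CC2`: in an ADME assay on BJ cells (Homo sapiens) for cytotoxicity, with a stated time of 72 h (a lower number here means that less compound is needed, a higher number that more compound is needed for the effect), compound 1 gives > 90000 nM, which is a limit of the assay.
Compound 2 `CC(C)C1=CC[C@H](C(=O)O)[C@@]12C=CC(=O)CC2`: compound 2 gives > 90000 nM, again a limit.
Compound 3 `CCOC[C@H]1CC=C(C(C)C)[C@]12C=CC(=O)CC2`: compound 3 gives > 90000 nM, also a limit.

Compound 3 therefore stands at the limit of > 90000 nM in this assay, at which 3 of the 3 values shown sit, and no number separates it from the other two. The change to compound 4 `CC(C)C1=CC[C@H](C(N)=O)[C@@]12C=CC(=O)CC2` is carbamoyl in place of ethoxymethyl on a saturated ring carbon. The measured steps touching this position, a step that the two limits leave unreadable from compound 2 to compound 3 and a step that the two limits leave unreadable from compound 1 to compound 2, are both unreadable, since every value sits at the limit, so no size or direction can be taken from them. The expectation in this assay is thus a step that the limit leaves unreadable from compound 3 to compound 4, which is no step beyond the scatter, and compound 4 is estimated at 100000 nM, between 30000 nM and 300000 nM.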

Compound 4, half-maximal effective concentration: > 90000 nM
Compound 4 ended at the assay's limit (the forecaster's own chance of this, stated with the estimate: 85%); the middle value is on the limit's open side.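

No step can be read from compound 4 to compound 1, compound 2 or compound 3, since all four stand at one limit: the limit of > 90000 nM in this assay, at which 4 of the 4 values shown sit. The compounds shown leave open whether any of these changes on a saturated ring carbon alters the result in this assay.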